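From 1,1-dimethylpropoxy to methoxy on the shared core

The compounds below may be only part of what the source reports. "The series", "measured", "known", "first", "only" and "open" are said of these compounds alone.

Measured in a functional assay on PC-12 cells (Rattus norvegicus) for inhibition, read by sulforhodamine B assay; on this read-out lower numbers stand for stronger inhibition and higher numbers for weaker inhibition:
- compound 1 `CCC(C)(C)Oc1ccc(CC2SC(=O)NC2=O)cc1`: 23000 nM
- compound 2 `CCC(C)(C)Oc1ccc(/C=C2\SC(=O)NC2=O)cc1`: 15000 nM

Within the data shown here, compound 1 and compound 2 lie within the scatter of each other, so compound 1 stands level with the only other measured compound. Compound 3 `COc1ccc(CC2SC(=O)NC2=O)cc1` keeps the core of compound 1 and carries methyl in place of 1,1-dimethylpropyl on an oxygen on an aromatic ring. Among the measured compounds shown here, no measured pair shows this change, so the expectation rests on the structural change alone: a moderate rise in the number in this assay, towards weaker inhibition. The expected move is a 1.7-fold higher number from compound 1 to compound 3 (0.24 log units; within the scatter). For compound 3 the estimated value is 40000 nM, with an expected range of 15000 nM to 100000 nM.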

Compound 3, half-maximal inhibitory concentration: > 100000 nM
Compound 3: only a limit was reported (the forecaster's own chance of this, stated with the estimate: 20%); middle value at least 2.5-fold (0.39 log units) from the limit.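

In this assay compound 3 gives only a limit of the assay, > 100000 nM. Going from 1,1-dimethylpropoxy to methoxy on the shared core gives an at least 4.3-fold higher number from compound 1 to compound 3 (0.63 log units; beyond the scatter), so the group on this oxygen does affect the read-out, which compounds 1 and 2 alone could not show. The true size of this step stays unknown, as it rests on a limit: the limit of > 100000 nM in this assay, at which 1 of the 3 values shown sits.

Open, from the compounds shown here alone, is whether a chain of intermediate length, such as ethoxy or isopropoxy, keeps the number near that of compound 1. Also open, going by these compounds, is how an amine at this place would read.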